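Phenyl for cyano on the arylpiperazine ring

A few compounds are considered here, and "the series" means these few. Any claim that something is new, unique, unknown or untested is made for them only; others in the source may bear on it.

Three compounds of the series have numbers. Compound 1 `COc1ccccc1N1CCN(CCCNc2ncccc2C(=O)C2CC2)CC1` gives 0.501 nM in a functional assay for antagonist activity at Alpha-1A adrenergic receptor (Oryctolagus cuniculus); a lower number here means tighter binding, a higher number weaker binding. Compound 2 `COc1ccccc1N1CCN(CCCNc2ccccc2C(=O)c2ccccc2)CC1` gives 31.6 nM in this assay. Compound 3 `CN(C)C(=O)c1cccnc1NCCCN1CCN(c2ccccc2C#N)CC1` gives 2 nM in this assay. Compound 3 thus stands second highest of the three: compound 1 sits lower by a margin beyond the scatter, compound 2 sits higher by a wider margin, also beyond the scatter.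

Compound 4 `CN(C)C(=O)c1cccnc1NCCCN1CCN(c2ccccc2-c2ccccc2)CC1` differs from compound 3 by phenyl in place of cyano on an aromatic carbon. For the measured compounds named here, no pair of measured compounds differs in one place only, so no measured step guides this change, and none of the measured compounds carries a phenyl at this position. The change is expected to shift the number upward by a moderate amount, beyond the scatter, as the estimated step of a 4.0-fold higher number from compound 3 to compound 4 (0.60 log units; beyond the scatter) shows. Compound 4 is expected to give about 8 nM in this assay, with a plausible range from 1.5 nM to 40 nM.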

Compound 4, dissociation constant: 1.26 nM
The estimate for compound 4 lay 6.3-fold (0.80 log units) above the measured number; measured number below the stated range.
By their numbers in this assay, from the lowest: compound 1; then compounds 4 and 3 (each within the scatter of the next); then compound 2.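

In this assay, exchanging cyano for phenyl gives a 1.6-fold lower number from compound 3 to compound 4 (0.20 log units; within the scatter). On this aromatic carbon, ortho to a large group, phenyl with its 6 heavy atoms thus shows no readable shift against cyano with its 2 heavy atoms. The pair also gives up the hydrogen-bond acceptor counted on cyano, and the two numbers still lie within the scatter of each other. Nothing at hand gives a reason for this result.

Open, on these data alone, is how an amine or a carboxylic acid on this same carbon would read in this assay. Also open, as far as these compounds go, is whether phenyl at this carbon gives a comparable number on the core of compound 1.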